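Extending the propanoyl chain of compound 2

A few compounds are considered here, and "the series" means these few. Any claim that something is new, unique, unknown or untested is made for them only; others in the source may bear on it.

Of the compounds shown here, two with a shared core have been measured so far in a functional assay on HepG2 cells (Homo sapiens) for antiproliferative activity, read by MTT assay, with a stated time of 72 h; a lower number here means a stronger inhibitor, a higher number a weaker inhibitor. Compound 1 (`COc1ccc(-c2cnc3scc(C(=O)NNC(C)=O)n23)cc1`) gives 11800 nM as its half-maximal inhibitory concentration. Compound 2 (`CCC(=O)NNC(=O)c1csc2ncc(-c3ccc(OC)cc3)n12`) gives 45800 nM and holds the higher of the two numbers, which makes it the weaker inhibitor of the pair.

Compound 3 (`CCCC(=O)NNC(=O)c1csc2ncc(-c3ccc(OC)cc3)n12`) carries one change (methyl in place of hydrogen on a saturated chain carbon, two bonds along the chain from a carbonyl carbon): methyl in place of hydrogen on a saturated chain carbon, two bonds along the chain from a carbonyl carbon. Propanoyl thereby becomes propylcarbonyl.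

For the measured compounds named here, only one measured step bears on this change. It is also a methyl in place of hydrogen, on a saturated chain carbon bound to a carbonyl carbon (a 3.9-fold higher number from compound 1 to compound 2 (0.59 log units; beyond the scatter)), and it is modest but beyond the scatter. One step cannot establish a trend, and the new methyl sits further along the chain, so a result within the scatter remains possible. In this assay the expected step is a smaller rise in the same direction (a 1.4-fold higher number from compound 2 to compound 3 (0.15 log units; within the scatter)). For compound 3 the estimated value is 65000 nM (from 25000 nM to 160000 nM).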

Compound 3, half-maximal inhibitory concentration: 38000 nM
The estimate for compound 3 lay 1.7-fold (0.23 log units) above the measured number; the measured number falls inside the stated range.
By their numbers in this assay, from the lowest: compound 1; then compounds 3 and 2 (each within the scatter of the next).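

In this assay, the added methyl gives a 1.2-fold lower number from compound 2 to compound 3 (0.08 log units; within the scatter) and so does not separate the two compounds, which shows that lengthening the chain at this place, two bonds along the chain from a carbonyl carbon, does not repeat the earlier step of a 3.9-fold higher number from compound 1 to compound 2 (0.59 log units; beyond the scatter) seen on the carbon bound to a carbonyl carbon. Read from compound 1, the whole ethyl in place of hydrogen gives a 3.2-fold higher number from compound 1 to compound 3 (0.51 log units; beyond the scatter) and lies beyond the scatter, so in these three compounds the separation from compound 1 is already there with the shorter of the two longer chains and the further carbon leaves it in place. Nothing available here explains why the first added carbon separates the compounds and the second does not.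

The compounds shown leave open whether a longer chain would stay level with compounds 2 and 3 or would move the number in either direction. They also leave open whether an amine or a carboxylic acid in place of the new methyl would change the number at this place, where methyl did not.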